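The source may hold more compounds than are shown below. What is called first, only, known or untested is meant among the compounds shown, and "the series" means these compounds.

Measured compounds in an assay on isolated protein for binding affinity to Leucine-rich repeat serine/threonine-protein kinase 2 variant G2019S (Homo sapiens), read by TR-FRET and LanthaScreen, with a stated time of 2 h; a higher number here means a weaker inhibitor, a lower number a stronger inhibitor:
- compound 1, `C[C@@H]1CCCN1c1c(C#N)c2c(N)nc(Nc3ccn(C)n3)cc2n1C`: 13 nM
- compound 2, `Cn1c(N2CCCC2)c(C#N)c2c(N)ncnc21`: 125 nM
- compound 3, `Cn1c(-n2cccc2)c(C#N)c2c(N)ncnc21`: 1980 nM

Compound 1 stands lowest of the three in this assay. Its nearest neighbour is compound 2, which gives 125 nM; compound 3, with 1980 nM, lies furthest away. For the measured compounds named here, the one single-point step among the measured compounds, a 16-fold higher number from compound 2 to compound 3 (1.20 log units; beyond the scatter), concerns the group on the shared core that carries the saturated or aromatic five-membered nitrogen ring, not the amino-linked pyrazole side.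

Compound 4, `Cc1cn(C)nc1Nc1cc2c(c(N)n1)c(C#N)c(N1CCC[C@H]1C)n2C`, is not yet measured. It differs from compound 1 only by methyl in place of hydrogen on an aromatic carbon. Going by the values given here, no measured pair in this set changes a substituent on the pyrazole, so the step from compound 1 to compound 4 has no direct precedent here; the step from compound 2 to compound 3 touches another part of the molecule and cannot be read across. With one carbon added and no new donor or acceptor, the working expectation is a step that stays within the usual scatter, with no clear direction.

Compound 4 is therefore expected to give about 15 nM in this assay, within a range of 6 nM to 40 nM. This estimate corresponds to a 1.2-fold higher number from compound 1 to compound 4 (0.06 log units; within the scatter), which is expected to be inside the scatter.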

Compound 4, inhibition constant: 75 nM
The estimate for compound 4 lay 5.0-fold (0.70 log units) below the measured number; measured number above the stated range.
By their numbers in this assay, from the lowest: compound 1; then compounds 4 and 2 (each within the scatter of the next); then compound 3.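

In this assay, methyl in place of hydrogen on an aromatic carbon of the pyrazole, next to the ring atom that bears a large group, gives a 5.8-fold higher number from compound 1 to compound 4 (0.76 log units; beyond the scatter). For the compounds shown here, this is the first reading on the (1-methyl-1H-pyrazol-3-yl)amino side of the series, and it shows that a single added carbon at this position is enough to raise the number beyond the scatter, although compound 4 still gives 75 nM in this assay. The earlier step, a 16-fold higher number from compound 2 to compound 3 (1.20 log units; beyond the scatter), concerned only the five-membered nitrogen ring elsewhere on the shared core, so it gave no information on this position, and nothing in hand accounts for the step seen here.

The compounds shown leave open whether the change depends on the size or the nature of the added group, as an ethyl group, a chlorine atom or a methoxy group on the same aromatic carbon would indicate. Going by these compounds alone, they also leave open whether the same methyl step would appear with pyrrolidin-1-yl in place of the 2-methylpyrrolidin-1-yl group, since this single pair is the only reading at this position.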